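Swapping One Side Group on a Shared Core

The source may hold more compounds than are shown below. What is called first, only, known or untested is meant among the compounds shown, and "the series" means these compounds.

- compound 1 `C=C1C(=O)O[C@@H]2CC(C)=C([C@@H](C)CCCOC(C)=O)[C@@H](OC(=O)CN(CC)CC)[C@H]12`: 13100 nM
- compound 2 `C=C1C(=O)O[C@@H]2CC(C)=C([C@@H](C)CCCOC(C)=O)[C@@H](OC(=O)COc3cccc(C(C)=O)c3)[C@H]12`: 45500 nM
- compound 3 `C=C1C(=O)O[C@@H]2CC(C)=C([C@@H](C)CCCOC(C)=O)[C@@H](OC(=O)COc3cccc4[nH]nnc34)[C@H]12`: 23700 nM

These three values come from a functional assay on HCT-116 cells (Homo sapiens) for cytotoxicity, read by sulforhodamine B assay, with a stated time of 72 h; on this read-out lower numbers stand for stronger inhibition and higher numbers for weaker inhibition. The compounds share one core and differ only in the side group attached through a carbonyl carbon. Compound 3 lies within the usual scatter of both neighbours: the steps are a 1.8-fold higher number from compound 1 to compound 3 (0.26 log units; within the scatter) and a 1.9-fold lower number from compound 2 to compound 3 (0.28 log units; within the scatter). Its value therefore cannot be firmly ranked against either of them.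

The next compound is compound 4 `C=C1C(=O)O[C@@H]2CC(C)=C([C@@H](C)CCCOC(C)=O)[C@@H](OC(=O)c3ccc(F)cc3)[C@H]12`, which keeps the core and changes the side group: a group of 7 heavy atoms (6 carbon, 1 fluorine; one six-membered aromatic ring of carbon only) in place of a group of 11 heavy atoms (7 carbon, 3 nitrogen, 1 oxygen; one five-membered aromatic ring with 3 hetero atoms, one six-membered aromatic ring of carbon only), on a carbonyl carbon. Going by the values given here, the most useful guide is how much the side-group swaps have moved the number so far. The largest, a 3.5-fold higher number from compound 1 to compound 2 (0.54 log units; beyond the scatter), was modest, while the other two stayed within the scatter. Three quite different groups thus gave values in one narrow band, so no step beyond the scatter is expected in this assay. Among the compounds with values here, none of the measured compounds carries 4-fluorophenyl, which leaves the range wide.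

The estimate means a 1.3-fold lower number from compound 3 to compound 4 (0.12 log units; within the scatter), an expected step within the scatter. For compound 4 the estimated value is 18000 nM, with an expected range from 6000 nM to 50000 nM.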

Compound 4, half-maximal inhibitory concentration: 14900 nM
For compound 4 the middle estimate is 1.2-fold (0.08 log units) above the measured one; the measured number falls inside the stated range.
By their numbers in this assay, from the lowest: compounds 1, 4, 3 and 2 (each within the scatter of the next, the first and the last beyond it).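

Going by these compounds alone, compound 4 is the first of the series to carry an aromatic ring, 4-fluorophenyl, on the carbonyl carbon without the saturated chain carbon that the other three have at that point, and in this assay this shorter group with no hydrogen-bond donors or acceptors still matches the others closely: a 1.1-fold higher number from compound 1 to compound 4 (0.06 log units; within the scatter) and a 1.6-fold lower number from compound 3 to compound 4 (0.20 log units; within the scatter). Only the comparison with the 3-acetylphenoxy compound goes beyond the scatter, and modestly, with a 3.1-fold lower number from compound 2 to compound 4 (0.48 log units; beyond the scatter); this shows that neither the chain carbon nor the nitrogen atoms of the groups in compounds 1 and 3 are needed to stay level with those two compounds, although compound 2 stands apart from compounds 1 and 4 while remaining within the scatter of compound 3. Nothing available explains why such different groups give such similar numbers.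

Going by these compounds, it remains open whether a carboxylic acid, a primary amine or a longer chain ending in 4-fluorophenyl on this carbonyl carbon would move the number further than any step seen so far. On these data alone, it is also open whether phenyl without the fluorine would give a value in the same band.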